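The source may report more compounds than this note shows. Statements on the series, on what has been measured and on what is new or still open speak of the compounds shown alone.

Measured so far: compound 1 `C=CCn1c(=S)n(C2OC(COCc3ccccc3)[C@H]3OC(C)(C)O[C@@H]23)c2nc(N)nc(O)c21`, 77%; compound 2 `[N-]=[N+]=NCC(O)Cn1c(=O)n(C2OC(CO)[C@@H](O)[C@H]2O)c2nc(N)nc(O)c21`, 91%; compound 3 `C=CCn1c(=O)n(C2OC(CO[Si](C)(C)C(C)(C)C)[C@@H](O)[C@H]2O)c2nc(N)nc(O)c21`, 5%.

All three numbers come from a functional assay on the whole organism (B cells) with Mus musculus as the target; on this read-out lower numbers stand for smaller maximal responses and higher numbers for larger maximal responses. Among them compound 2 stands highest. Its nearest neighbour is compound 1, whose number lies lower by more than the usual scatter, and compound 3 lies far below it, also beyond the scatter. Compound 4 `Nc1nc(O)c2c(n1)n(C1OC(CO)[C@@H](O)[C@H]1O)c(=O)n2CCN1CCCCC1` has not yet been measured. It differs from compound 2 in one place: (piperidin-1-yl)methyl in place of 2-azido-1-hydroxyethyl on a saturated chain carbon bound to an aromatic nitrogen. No pair of measured compounds tracks a change of this kind, so the expectation rests only loosely on the three numbers shown. A modest downward step is expected, a number 19 percentage points lower from compound 2 to compound 4 (beyond the scatter), which may or may not reach beyond the scatter. Compound 4 is thus expected to give about 72%, within a range from 35% to 95%.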

Compound 4, largest response reached (reported as maximal response), in percent of the reference or control that the assay uses: 0%
Compound 4: the middle estimate sits 72 percentage points above what was measured; measured number outside the range, below it.
By their numbers in this assay, from the lowest: compounds 4 and 3 (each within the scatter of the next); then compound 1; then compound 2.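

Replacing 2-azido-1-hydroxyethyl with (piperidin-1-yl)methyl on a saturated chain carbon bound to an aromatic nitrogen gives, in this assay, a number 91 percentage points lower from compound 2 to compound 4 (beyond the scatter). Within the data shown here, this is the first single-place change that can be read here, and it shows that the response depends strongly on the group at this position. Nothing at hand explains the size of this step.

The change swaps the whole group at once, so the piperidine ring is not separated from the loss of the azide or the hydroxyl. Going by these compounds, the effect of an open-chain dimethylamino group, or of a longer chain carrying the piperidine ring, also stays open.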